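The source may hold more compounds than are shown below. What is called first, only, known or untested is meant among the compounds shown, and "the series" means these compounds.

Compound 2 `Cc1ncnc2c1c(-c1cc3ccccc3o1)cn2[C@@H]1O[C@H](CO)[C@@H](O)[C@H]1O` stands at the edge of what a functional assay on K562 cells (Homo sapiens), read by MTT assay, with a stated time of 72 h (on this read-out higher numbers stand for weaker inhibition and lower numbers for stronger inhibition), can resolve. For compound 2 the reported value > 20000 nM is a limit of the assay and not a number, as shown by the limit of > 20000 nM in this assay, at which 1 of the 2 values shown sits. Among the measured compounds shown here, its one measured neighbour, compound 1 `C#Cc1cn([C@@H]2O[C@H](CO)[C@@H](O)[C@H]2O)c2ncnc(C)c12`, carries ethynyl where compound 2 carries 1-benzofuran-2-yl, and in this assay compound 1 gives 110 nM. For the measured compounds named here, the only measured step, an at least 180-fold higher number from compound 1 to compound 2 (2.25 log units; beyond the scatter), is the one that bears on the change now considered. Compound 3 `Cc1ncnc2c1c(-c1cccs1)cn2[C@@H]1O[C@H](CO)[C@@H](O)[C@H]1O` differs from compound 2 in this way: thiophen-2-yl in place of 1-benzofuran-2-yl on an aromatic carbon. Thiophen-2-yl brings fewer heavy atoms and one aromatic ring rather than two. Since the change to the larger 1-benzofuran-2-yl cost a great deal, a partial return is expected, though its size is uncertain. Compound 3 is therefore estimated at 5000 nM, with a range from 500 nM to 20000 nM. That estimate corresponds to an expected step of an at least 4.0-fold lower number from compound 2 to compound 3 (0.60 log units; beyond the scatter).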

Compound 3, half-maximal inhibitory concentration: > 20000 nM
Compound 3: only a limit was reported (the forecaster's own chance of this, stated with the estimate: 35%); at least 4.0-fold (0.60 log units) between middle value and limit.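

In this assay compound 3 gives > 20000 nM, which is a limit of the assay and not a number. The loss at this aromatic carbon therefore does not depend on the second aromatic ring of 1-benzofuran-2-yl: thiophen-2-yl, with one five-membered aromatic ring, still leaves an at least 180-fold higher number from compound 1 to compound 3 (2.25 log units; beyond the scatter). The step that joins compound 2 and compound 3 cannot be read, and the two aromatic groups cannot be ranked, because both compounds sit at the same limit: the limit of > 20000 nM in this assay, at which 2 of the 3 values shown sit.

Among the compounds shown, only compound 1, with ethynyl, gives a readable number, so how far each aromatic compound lies past the limit stays open. Also open, as far as these compounds go, is whether a nitrile, a vinyl group or an aminomethyl group on this aromatic carbon would give a readable number.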